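The source may report more compounds than this note shows. Statements on the series, on what has been measured and on what is new or still open speak of the compounds shown alone.

Values in a functional assay on cells (Homo sapiens) for cytotoxicity, read by MTT assay, with a stated time of 24 h; a lower number here means a stronger inhibitor, a higher number a weaker inhibitor:
- compound 1 `CCCCCCCCCCCCCCNC(=O)[C@H](CO)/N=C/c1cccc(C)c1`: 82900 nM
- compound 2 `CCCCCCCCCCCCCCNC(=O)[C@H](CO)/N=C/c1ccc(OC)cc1`: 28100 nM
- compound 3 `CCCCCCCCCCCCCCNC(=O)[C@H](CO)/N=C/c1ccccc1OC`: 12500 nM

Compound 3 has the lowest number of the three measured compounds. It lies below the others by a 2.2-fold lower number from compound 2 to compound 3 (0.35 log units; beyond the scatter) and a 6.6-fold lower number from compound 1 to compound 3 (0.82 log units; beyond the scatter). The next structure is compound 4 `CCCCCCCCCCCCCCNC(=O)[C@H](CO)NCc1ccccc1O`, which keeps the shared core but carries (2-hydroxybenzyl)amino on a saturated chain carbon bound to a carbonyl carbon and a saturated chain carbon. The change is a group of 9 heavy atoms (7 carbon, 1 nitrogen, 1 oxygen; one six-membered aromatic ring of carbon only) in place of a group of 10 heavy atoms (8 carbon, 1 nitrogen, 1 oxygen; one six-membered aromatic ring of carbon only), on a saturated chain carbon bound to a carbonyl carbon and a saturated chain carbon.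

The measured steps bear on this change only indirectly. Each one swaps the aryl group on the carbon with a double bond to nitrogen, and all are modest: a 3.0-fold lower number from compound 1 to compound 2 (0.47 log units; beyond the scatter), alongside the two steps above. None of them covers the loss of that double bond, so the series gives no measured direction for this change. The largest, a 6.6-fold lower number from compound 1 to compound 3 (0.82 log units; beyond the scatter), serves only as a rough scale for the uncertainty. A small move to a lower number is tentatively expected, with the estimated step being a 1.8-fold lower number from compound 3 to compound 4 (0.25 log units; within the scatter). A move to a higher number is not excluded. For compound 4 the estimated value in this assay is 7000 nM, with an expected range of 2500 nM to 20000 nM.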

Compound 4, half-maximal inhibitory concentration: 75300 nM
The estimate for compound 4 lay 11-fold (1.03 log units) below the measured number, and the stated range ends below it.
By their numbers in this assay, from the lowest: compound 3; then compound 2; then compounds 4 and 1 (each within the scatter of the next).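

Working notes on the series. In this assay, for the compounds shown here, this is the first change at the saturated chain carbon bound to a carbonyl carbon and a saturated chain carbon that removes the double bond to nitrogen, and the aryl-only steps gave no direction for it: the move to (2-hydroxybenzyl)amino gives a 6.0-fold higher number from compound 3 to compound 4 (0.78 log units; beyond the scatter) and a 2.7-fold higher number from compound 2 to compound 4 (0.43 log units; beyond the scatter), so this position is sensitive and the change goes toward a higher number against both methoxy compounds. Against the 3-methylphenyl compound the same change gives only a 1.1-fold lower number from compound 1 to compound 4 (0.04 log units; within the scatter), so that pair cannot be told apart and the size of the step depends on the group it replaces. The step from the 2-methoxyphenyl compound combines loss of the double bond with hydroxy in place of methoxy, and nothing on hand offers an explanation for the result.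

Still open, on these data alone, is which of those two differences carries the step; 2-methoxybenzylamino, or 2-hydroxyphenyl on a carbon with a double bond to nitrogen, would separate them. As far as these compounds go, how a plain amino group on this saturated chain carbon would compare also remains open.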